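This account rests on a few compounds, and the source may have more. Where it says the series, first, only, none or still open, it means among the compounds named here.

The shared core appears in compound 1 `COc1cc(-c2ccnc3c(-c4ccc(C)cc4)cnn23)cc(OC)c1OC`, compound 2 `COc1cc(-c2cc3nccc(-c4c[nH]c5ccccc45)n3n2)cc(OC)c1OC` and compound 3 `COc1cc(-c2ccnc3cc(-c4ccc(-c5cnn(C)c5)cc4)nn23)cc(OC)c1OC`, each carrying a different aromatic substituent at one position while the rest is held constant. All three were tested in a functional assay on A549 cells (Homo sapiens) for inhibition, read by CCK-8 assay, with a stated time of 48 h; a higher number here means a weaker inhibitor, a lower number a stronger inhibitor. Compound 1 reached only the limit of > 10000 nM in this assay. Compound 2 likewise gave only the limit of > 10000 nM. Among the compounds with values here, compound 3 is the one compound with an actual number, and in this assay compound 3 gives 1150 nM. Within the data shown here, two of the three results are limits, as the limit of > 10000 nM in this assay, at which 2 of the 3 values shown sit, records, so compound 3 stands alone as the single measured value, with no second number to set beside it.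

Compound 4 `COc1cc(-c2ccnc3cc(-c4ccc(C(F)(F)F)cc4)nn23)cc(OC)c1OC` has not been measured. It differs from compound 3 in one place: trifluoromethyl in place of 1-methyl-1H-pyrazol-4-yl on an aromatic carbon. Among the measured compounds shown here, no step between two measured compounds is available to show how much such an exchange shifts the result. For the measured compounds named here, with only a single number behind it, the expectation for compound 4 is cautious, and the step of a 2.2-fold higher number from compound 3 to compound 4 (0.34 log units; beyond the scatter) is expected to sit near the edge of the usual scatter, leaning toward weaker inhibition. Compound 4 is therefore estimated at 2500 nM, within a range from 700 nM to 10000 nM.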

Compound 4, half-maximal inhibitory concentration: 2070 nM
Compound 4: the middle estimate sits 1.2-fold (0.08 log units) above what was measured; low and high end bracket the measured number.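

In this assay, putting trifluoromethyl in place of 1-methyl-1H-pyrazol-4-yl gives a 1.8-fold higher number from compound 3 to compound 4 (0.26 log units; within the scatter), so the two groups cannot be told apart in this measurement. This is the first pair among the compounds shown that differs in only one place, which makes it the first direct reading of a change at this position. On this aromatic carbon, para to a large group, a five-membered aromatic ring with 2 hetero atoms and 2 hydrogen-bond acceptors can give way to a group with no ring and 0 hydrogen-bond acceptors without a shift beyond the usual scatter, at least in this one pair.

Going by these compounds, whether an amine, a carboxylic acid or a longer chain at the same place would leave the result within the scatter of compound 3 or move it clearly in either direction remains open. The data shown also offer no measured property that would explain why these two quite different groups give results within the scatter of each other.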